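Furan-2-yl in Place of Phenyl on a Shared Core

The compounds below may be only part of what the source reports. "The series", "measured", "known", "first", "only" and "open" are said of these compounds alone.

Compound 1 `COc1ccc(Nc2cc(C3CCCCC3)oc(=O)c2)cc1` gives 4.39 uM in a functional assay on KBVIN cells (Homo sapiens) for cytotoxicity, read by MTT assay, with a stated time of 72 h; on this read-out higher numbers stand for an effect only at larger amounts of compound and lower numbers for an effect already at smaller amounts.
Compound 2 `COc1ccc(Nc2cc(-c3ccccc3)oc(=O)c2)cc1` gives 0.098 uM in this assay.

Compound 2 has the lowest of the two numbers. Within the data shown here, the only measured step, a 45-fold lower number from compound 1 to compound 2 (1.65 log units; beyond the scatter), swapped a saturated ring for an aromatic one and was large. Compound 3 `COc1ccc(Nc2cc(-c3ccco3)oc(=O)c2)cc1` differs from compound 2 by furan-2-yl in place of phenyl on an aromatic carbon. Among the measured compounds shown here, no measured step covers a swap between two aromatic rings, so the change is expected to be smaller than that step. Compound 3 is expected to give 0.2 uM, between 0.05 uM and 1 uM. The expected step is a 2.0-fold higher number from compound 2 to compound 3 (0.31 log units; beyond the scatter).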

Compound 3, concentration for half-maximal effect: 1.46 uM
Beside the measured number, compound 3's estimate is 7.3-fold (0.86 log units) below it; the whole stated range lies below it.
By their numbers in this assay, from the lowest: compound 2; then compound 3; then compound 1.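

This position separates one aromatic ring from another: furan-2-yl in place of phenyl gives a 15-fold higher number from compound 2 to compound 3 (1.17 log units; beyond the scatter) and shows that an aromatic ring here does not by itself bring the low number of compound 2. Furan-2-yl in place of cyclohexyl gives a 3.0-fold lower number from compound 1 to compound 3 (0.48 log units; beyond the scatter) and so recovers only part of the gain seen with phenyl. Nothing available explains the difference between the two aromatic rings.

On these data alone, it remains open how thiophen-2-yl or pyridin-3-yl would compare at this place. As far as these compounds go, whether a phenyl carrying a methoxy group or an amine would keep the number of compound 2 is also open.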